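The source may report more compounds than this note shows. Statements on the series, on what has been measured and on what is new or still open speak of the compounds shown alone.

Compound 1 `COc1ccccc1Oc1c(N)nc(-c2cccc(C)c2)nc1Cl` and compound 2 `COc1ccccc1Oc1c(N)nc(-c2cccc(Cl)c2)nc1Cl` share one core and differ only in a single substituent on the 3-methylphenyl group. In a functional assay on SK-MEL-28 cells (Homo sapiens) for cytotoxicity, read by CCK-8 assay, with a stated time of 24 h (on this read-out higher numbers stand for weaker inhibition and lower numbers for stronger inhibition), compound 1 gives 54000 nM, and compound 2 gives 19400 nM. Within the data shown here, of the two numbers measured so far, compound 1 stands highest, that is, it is the weaker inhibitor, and the one step between measured compounds, a 2.8-fold lower number from compound 1 to compound 2 (0.44 log units; beyond the scatter), is modest but beyond the scatter.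

Compound 3 `COc1ccccc1Oc1c(N)nc(-c2cccc(C)c2)nc1OCCO` is not yet measured. It departs from compound 1 at a different place: 2-hydroxyethoxy in place of chloro on an aromatic carbon. Among the measured compounds shown here, no measured step touches this position or this kind of exchange; the only step known, from compound 1 to compound 2, sits on the 3-methylphenyl group instead and so gives no guide to the size or direction of the present change. The expectation for compound 3 therefore rests on compound 1 alone, with a wide range. Compound 3 is estimated at 70000 nM, most likely between 20000 nM and 250000 nM. That estimate means a step of a 1.3-fold higher number from compound 1 to compound 3 (0.11 log units; within the scatter), expected to lie within the scatter.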

Compound 3, half-maximal inhibitory concentration: 14700 nM
Estimate against measurement, compound 3: 4.8-fold (0.68 log units) above, and the stated range ends above it.
By their numbers in this assay, from the lowest: compounds 3 and 2 (each within the scatter of the next); then compound 1.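

In this assay, putting 2-hydroxyethoxy in place of chloro gives a 3.7-fold lower number from compound 1 to compound 3 (0.57 log units; beyond the scatter), so the number falls rather than rises at this position. The chloro group is therefore not required for the activity of compound 3, and this place on the shared core accepts a chain of 4 heavy atoms with a modest gain, something the earlier pair could not show since it changed only the other end of the molecule. Nothing available here explains why the number falls with this exchange.

From the compounds shown here alone, what remains open is which part of the new chain matters: a methoxy group, an ethoxy group without the terminal hydroxyl, a longer chain such as 3-hydroxypropoxy, or an amine at the same place would each help separate the effect of chain length from that of the hydroxyl end. Going by these compounds, it is also open whether the same exchange of chloro for 2-hydroxyethoxy would give a step of similar size and direction when made on compound 2.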